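The source may report more compounds than this note shows. Statements on the series, on what has been measured and on what is new or still open speak of the compounds shown alone.

Notes on a set of esters that share one core, compared in a functional assay on HeLa cells (Homo sapiens) for inhibition, read by MTT assay, with a stated time of 24 h; on this read-out lower numbers stand for stronger inhibition and higher numbers for weaker inhibition.

Compound 2 `CCOC(=O)C1=Cc2ccccc2OC1(OCc1cc(-c2ccc(Br)cc2)no1)C(F)(F)F` gives 52300 nM in this assay, the higher of the two numbers available. Compound 3 `CCOC(=O)C1=Cc2ccccc2OC1(OCc1cn(-c2ccc(F)c([N+](=O)[O-])c2)nn1)C(F)(F)F` gives 15600 nM in this assay, the nearest value, well beyond the scatter from compound 2. Compound 1 `CCOC(=O)C1=Cc2ccccc2OC1(OCc1cn(CC(=O)Nc2cccc(F)c2)nn1)C(F)(F)F` reports only a limit in this assay, > 150000 nM; this is the limit of > 150000 nM in this assay, at which 1 of the 3 values shown sits. Within the data shown here, the single step between measured compounds, an at least 9.6-fold lower number from compound 1 to compound 3 (0.98 log units; beyond the scatter), concerns the group on an aromatic nitrogen of the core and does not touch the ring carbon altered below.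

Compound 4 `CCOC(=O)C1=Cc2ccccc2OC1(OCc1cc(-c2cccc(C(F)(F)F)c2)no1)C(F)(F)F` differs from compound 2 by 3-(trifluoromethyl)phenyl in place of 4-bromophenyl on an aromatic carbon. Among the measured compounds shown here, no measured step bears on this change, so nothing supports a shift in either direction beyond the usual scatter. The step expected for compound 4 is accordingly small, a 1.0-fold lower number from compound 2 to compound 4 (0.02 log units; within the scatter), with a wide uncertainty in both directions. Compound 4 is estimated at 50000 nM in this assay, within a range from 15000 nM to 150000 nM.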

Compound 4, half-maximal inhibitory concentration: 21400 nM
Compound 4: middle estimate off by 2.3-fold (0.37 log units), on the high side; the measured number falls inside the stated range.
By their numbers in this assay, from the lowest: compounds 3 and 4 (each within the scatter of the next); then compound 2. At a limit, above all of these: compound 1.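

In this assay, among these compounds, the first measured change to the aryl group on this aromatic carbon of the five-membered aromatic ring with 1 nitrogen and 1 oxygen gives a 2.4-fold lower number from compound 2 to compound 4 (0.39 log units; beyond the scatter) and so shows that the number responds to the group held at this position. The step is modest, and the pair changes both the substituent and its place on the phenyl ring, so the two contributions cannot be separated. No available evidence bears on why 3-(trifluoromethyl)phenyl and 4-bromophenyl differ here.

The compounds shown leave open how an unsubstituted phenyl would compare at this position. They also leave open whether a phenyl carrying an amine or a carboxylic acid would extend or reverse the step.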